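The source may report more compounds than this note shows. Statements on the series, on what has been measured and on what is new or still open speak of the compounds shown alone.

Three compounds sharing one core were measured in an assay on membranes from HEK293 cells for displacement of a labelled ligand from Neuronal acetylcholine receptor; alpha3/beta4 (Homo sapiens), with a stated time of 5 min; a lower number here means a stronger inhibitor, a higher number a weaker inhibitor. Compound 1 `CN1CCC[C@H]1[C@@H]1COc2ccc(N)cc2O1` gives 19 nM, compound 2 `CN1CCC[C@H]1[C@H]1COc2cc(N)ccc2O1` gives 8600 nM, and compound 3 `CN1CCC[C@H]1[C@H]1COc2c(N)cccc2O1` gives 13000 nM. Compound 3 has the highest number of the three; its gap to compound 2 lies within the scatter, while its gap to compound 1 lies far beyond it. Compound 1 differs from compound 3 in more than one respect, so the two values alone do not show which change accounts for the gap.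

Compound 4 `CN1CCC[C@H]1[C@@H]1COc2c(N)cccc2O1` is the next step: the two compounds have the same atoms and bonds and differ only in configuration as drawn: 1 of 2 stereo elements differ; a stereocentre at a saturated ring carbon is drawn S in compound 3 and R in compound 4. Going by the values given here, compound 1, the only compound with a low number, is drawn with the same configuration at that carbon as compound 4, which suggests the configuration may matter, though compound 1 also differs from compound 3 otherwise. A lower number is therefore expected, and the step from compound 3 to compound 4 in this assay is estimated at a 33-fold lower number from compound 3 to compound 4 (1.51 log units; beyond the scatter). Compound 4 is expected to give 400 nM, within a range of 30 nM to 5000 nM.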

Compound 4, inhibition constant: 3900 nM
For compound 4 the middle estimate is 9.8-fold (0.99 log units) below the measured one, and the stated range covers the measured number.
By their numbers in this assay, from the lowest: compound 1; then compound 4; then compounds 2 and 3 (each within the scatter of the next).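

The earlier compounds shown here offered no pair differing in one place, but in this assay the stereocentre at a saturated ring carbon can now be read on its own, as a 3.3-fold lower number from compound 3 to compound 4 (0.52 log units; beyond the scatter), a modest step. The step can be assigned to that carbon alone because nothing else changes: the fact that compounds 3 and 4 differ only in the configuration as drawn. The configuration there therefore counts, yet compound 4 gives 3900 nM while compound 1, drawn the same way at that carbon, gives 19 nM, so the R drawing alone does not bring the number down to that of compound 1.

Going by these compounds, whether the same inversion gives a step of like size in compound 1 or compound 2 remains open. So does whether a hydroxyl or methoxy group in place of the amine would keep or lose the low number of compound 1.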